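Swapping Phenyl for Ethyl on Compound 1

The compounds below may be only part of what the source reports. "The series", "measured", "known", "first", "only" and "open" are said of these compounds alone.

For the measured compounds named here, in a physicochemical assay for metabolic stability, read by HPLC, in phosphate buffer, at pH 7.4, tested at 10 uM (on this read-out lower numbers stand for a shorter-lived compound and higher numbers for a longer-lived compound), compound 1 (`O=C(NCCCCc1ccccc1)N1C(=O)c2ccccc2C1=O`) gives 0.1 h as the lowest of three numbers so far, while compound 2 (`O=C(NCCCCc1ccccc1)n1cnc2ccccc21`) gives 0.833 h and compound 3 (`CCCCCCNC(=O)n1cnc2ccccc21`) gives 0.983 h in the same measurement. Both of these stand beyond the scatter from compound 1. Compound 4 (`CCCCCCNC(=O)N1C(=O)c2ccccc2C1=O`), still unmeasured, carries ethyl in place of phenyl on a saturated chain carbon, four bonds along the chain from an amide-type nitrogen. Going by the values given here, the same exchange on the core of compound 2 gave a 1.2-fold higher number from compound 2 to compound 3 (0.07 log units; within the scatter) and is the only measured step bearing on this one. A similarly small change is therefore expected, with the estimated step being a 1.2-fold higher number from compound 1 to compound 4 (0.08 log units; within the scatter) and no shift beyond the scatter. For compound 4 the estimate is 0.12 h in this assay with an expected range from 0.06 h to 0.24 h as its bounds.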

Compound 4, half-life: 0.15 h
The estimate for compound 4 lay 1.3-fold (0.10 log units) below the measured number, and the stated range covers the measured number.
By their numbers in this assay, from the lowest: compounds 1 and 4 (each within the scatter of the next); then compounds 2 and 3 (each within the scatter of the next).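

In this assay the exchange of phenyl for ethyl now appears on a second core, with a 1.5-fold higher number from compound 1 to compound 4 (0.18 log units; within the scatter) alongside the earlier 1.2-fold higher number from compound 2 to compound 3 (0.07 log units; within the scatter) on the other. On both cores, the change on a saturated chain carbon, four bonds along the chain from an amide-type nitrogen, stays within the scatter. No measurement shown gives an explanation for this result. The compounds shown leave open whether an amine, a carboxylic acid or a longer chain in this place would move the number beyond the scatter.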